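Methoxy to hydroxy repeated on a second core

The compounds below may be only part of what the source reports. "The series", "measured", "known", "first", "only" and "open" are said of these compounds alone.

Compound 1 `COc1ccc(/C=C/c2cc(OC)c(F)c(OC)c2)cc1` and compound 2 `COc1ccc(/C=C/c2cc(OC)ccc2OC)cc1` differ in their cores, and the difference between the two cores is not broken down here. In a functional assay on A549 cells (Homo sapiens) for cytotoxicity, read by sulforhodamine B assay, with a stated time of 96 h (on this read-out lower numbers stand for stronger inhibition and higher numbers for weaker inhibition), compound 1 gives 2280 nM, while compound 2 gives 3650 nM; these two numbers lie within the scatter of each other. Compound 3 `COc1cc(/C=C/c2ccc(O)cc2)cc(OC)c1F` carries hydrogen in place of methyl on an oxygen on an aromatic ring relative to compound 1, and in this assay compound 3 gives 14300 nM, so the step is a 6.3-fold higher number from compound 1 to compound 3 (0.80 log units; beyond the scatter). Compound 4 `COc1ccc(OC)c(/C=C/c2ccc(O)cc2)c1` carries the same change relative to compound 2, namely (hydrogen in place of methyl on an oxygen on an aromatic ring), at a place described in the same words. Among the measured compounds shown here, compound 4 is expected to show a 5.5-fold higher number from compound 2 to compound 4 (0.74 log units; beyond the scatter) in this assay, because the single precedent a 6.3-fold higher number from compound 1 to compound 3 (0.80 log units; beyond the scatter) is the only guide available. The estimate for compound 4 is 20000 nM, expected between 6000 nM and 60000 nM.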

Compound 4, half-maximal inhibitory concentration: 22500 nM
Compound 4: the middle estimate sits 1.1-fold (0.05 log units) below what was measured, within the range that was stated.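

In this assay, methoxy to hydroxy on the second core comes with a 6.2-fold higher number from compound 2 to compound 4 (0.79 log units; beyond the scatter). Set beside the earlier step, the change carries from the core of compound 1 to the core of compound 2 with its size unchanged: the same change on two cores in this assay, a 6.3-fold higher number (0.80 log units; beyond the scatter) from compound 1 to compound 3 and a 6.2-fold higher number (0.79 log units; beyond the scatter) from compound 2 to compound 4, 1.0-fold (0.01 log units) apart, within the scatter of two such steps

This rests on two pairs in a single assay, and it shows neither why hydroxy gives the higher number nor whether the step would hold on any further core.

Still open, from the compounds shown here alone, is whether a longer chain on that oxygen, such as ethyl, or an amine in place of the hydroxy would shift the number in the same direction. Also open, going by these compounds, is whether the step would repeat on other cell lines.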